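Nitrofuran amides: cytotoxicity on Vero cells and a new analogue

The compounds below may be only part of what the source reports. "The series", "measured", "known", "first", "only" and "open" are said of these compounds alone.

Measured so far:
compound 1 `O=C(Nc1ccccc1)c1ccc([N+](=O)[O-])o1`, 6700 nM
compound 2 `O=C(NCc1ccc(Cl)cc1)c1ccc([N+](=O)[O-])o1`, 2800 nM
compound 3 `CC(C)(NC(=O)c1ccc([N+](=O)[O-])o1)c1ccc(OC(F)(F)F)cc1`, 70000 nM

All three share the nitrofuran carboxamide core and were tested in an ADME assay on Vero cells (Chlorocebus sabaeus) for cytotoxicity, read by MTT assay, with a stated time of 48 h; a lower number here means that less compound is tolerated, a higher number that more compound is tolerated. Compound 1 gives 6700 nM and compound 2 gives 2800 nM, both numbers lying beyond the scatter from compound 3, which gives 70000 nM, the highest of the three. No two of these compounds differ in one place only, so no single step can be read from them.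

Compound 4 `COc1ccc(OCc2ccc(C(C)(C)NC(=O)c3ccc([N+](=O)[O-])o3)cc2)cc1` is the next analogue. It differs from compound 3 in one place: (4-methoxyphenoxy)methyl in place of trifluoromethoxy on an aromatic carbon. Within the data shown here, the change brings in a second six-membered aromatic ring and a further acceptor, as counted above, but none of the measured pairs shows what such an exchange does in this assay. The step is therefore estimated from the position of compound 3 alone and from the general spread of the three numbers. Compound 4 is expected to give a somewhat lower number than compound 3, a step of a 1.8-fold lower number from compound 3 to compound 4 (0.24 log units; within the scatter), which may well lie within the scatter. The estimate for compound 4 in this assay is 40000 nM, with a range from 10000 nM to 150000 nM.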

Compound 4, half-maximal cytotoxic concentration: > 120000 nM
Compound 4 gave a limit, no number (the forecaster's own chance of this, stated with the estimate: 15%); middle value at least 3.0-fold (0.47 log units) away from the limit.
By their numbers in this assay, from the lowest: compound 2; then compound 1; then compound 3. At a limit, above all of these: compound 4.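

Compound 4 stands at a limit of this assay and gives no number: the limit of > 120000 nM in this assay, at which 1 of the 4 values shown sits. Among these compounds, the exchange of trifluoromethoxy for (4-methoxyphenoxy)methyl gives an at least 1.7-fold higher number from compound 3 to compound 4 (0.23 log units; that floor lies within the scatter), the first single step that can be read, and it is only a floor, so the true size of the step is unknown. It shows that this place, an aromatic carbon para to a large group, can carry a much larger substituent with a second six-membered aromatic ring without the number falling.

Going by these compounds, how far compound 4 lies past its limit stays open, as does whether the added ring or the added oxygen atoms matter more for the step. Also open, on these data alone, is what an amine or a carboxylic acid at this same place would do to the number.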